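Methoxy for Methyl on the Acid-Bearing Carbon

The source may report more compounds than this note shows. Statements on the series, on what has been measured and on what is new or still open speak of the compounds shown alone.

Of the compounds shown here, three have so far been measured in a functional assay on CHO cells for antagonist activity at sphingosine 1-phosphate receptor 2 (Homo sapiens), read by GTPgammaS binding; a lower number here means a stronger inhibitor, a higher number a weaker inhibitor. Compound 1 `CCOc1cc2nn(Cc3nn(CC(=O)O)c(=O)c4ccccc34)cc2cc1Cl` gives 113 nM in this assay. Compound 3 `O=C(O)Cn1nc(Cc2nc3cc(F)c(OCC4CC4)cc3[nH]2)c2ccccc2c1=O` gives 180 nM. Compound 2 `CC(C(=O)O)c1nn(Cc2cn3cc(OCC4CC4)c(Cl)cc3n2)c2ccccc2c1=O` gives 31 nM, the lowest of the three numbers; its separations from compound 1 and from compound 3 both lie beyond the usual scatter, so among the three it stands as the strongest inhibitor. Compound 4 `COC(C(=O)O)c1nn(Cc2cn3cc(OCC4CC4)c(Cl)cc3n2)c2ccccc2c1=O` has not yet been measured and differs from compound 2 in a single place: methoxy in place of methyl on a saturated chain carbon bound to an aromatic carbon and a carbonyl carbon. Going by the values given here, no pair of measured compounds shows this particular change, so there is nothing in the numbers themselves that fixes its size. The change keeps the carboxylic acid and its position and only alters the substituent on the same saturated chain carbon, so the step from compound 2 to compound 4 is expected to be small, most likely a modest move toward a higher number, and it may well stay within the scatter: a 1.6-fold higher number from compound 2 to compound 4 (0.21 log units; within the scatter). Compound 4 is accordingly estimated to give about 50 nM in this assay, with a plausible range from 20 nM to 150 nM.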

Compound 4, half-maximal inhibitory concentration: 58 nM
Estimate against measurement, compound 4: 1.2-fold (0.06 log units) below, within the range that was stated.
By their numbers in this assay, from the lowest: compounds 2, 4, 1 and 3 (each within the scatter of the next, the first and the last beyond it).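

In this assay the exchange of methyl for methoxy on the saturated chain carbon bound to an aromatic carbon and a carbonyl carbon amounts to a 1.9-fold higher number from compound 2 to compound 4 (0.27 log units; within the scatter) and so does not separate the two compounds. Going by these compounds alone, this pair gives the first direct reading of this position, because compound 2 and compound 4 differ only there, and it shows that the position accepts one more heavy atom and one hydrogen-bond acceptor, as counted for the methoxy group, without a step beyond the scatter. Nothing in the information at hand explains why the number holds across this change.

The compounds shown leave open how far this tolerance extends, since methyl and methoxy are the only groups seen on this carbon in the presence of the shared core of compound 2 and compound 4. Whether a hydroxyl, an ethoxy, a fluorine or an amine on the same carbon would also stay within the scatter of compound 2, or whether a longer chain would produce a step beyond it, cannot be read from this single pair.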